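The source may hold more compounds than are shown below. What is called first, only, known or untested is meant among the compounds shown, and "the series" means these compounds.

Measured in a functional assay on PC-3 cells (Homo sapiens) for inhibition, read by MTT assay, with a stated time of 48 h; on this read-out higher numbers stand for weaker inhibition of growth and lower numbers for stronger inhibition of growth:
- compound 1 `CN1CC[C@H](c2c(O)cc(O)c3c(=O)cc(/C=C/c4ccccc4)oc23)[C@H](O)C1`: 58000 nM
- compound 2 `CN1CC[C@H](c2c(O)cc(O)c3c(=O)cc(/C=C/c4cccc(Cl)c4)oc23)[C@H](O)C1`: 10000 nM
- compound 3 `CN1CC[C@H](c2c(O)cc(O)c3c(=O)cc(/C=C/c4c(F)c(F)c(F)c(F)c4F)oc23)[C@H](O)C1`: 2000 nM

Of these three, compound 3 gives the lowest number in this assay, and its steps to both others lie beyond the scatter. It is the most potent of the set, with a 5.0-fold lower number from compound 2 to compound 3 (0.70 log units; beyond the scatter) and a 29-fold lower number from compound 1 to compound 3 (1.46 log units; beyond the scatter).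

The next compound, compound 4 `CN1CC[C@H](c2c(O)cc(O)c3c(=O)cc(/C=C/c4cccc(F)c4)oc23)[C@H](O)C1`, has not yet been measured. It differs from compound 3 as follows: 3-fluorophenyl in place of 2,3,4,5,6-pentafluorophenyl on a double-bonded chain carbon bound to a double-bonded chain carbon. In words, 3-fluorophenyl stands in place of 2,3,4,5,6-pentafluorophenyl on a double-bonded chain carbon bound to a double-bonded chain carbon.

Going by the values given here, two measured steps bear most directly on this change. Compound 2 carries 3-chlorophenyl and shows a 5.0-fold lower number from compound 2 to compound 3 (0.70 log units; beyond the scatter), a modest step. The unsubstituted compound 1 marks the far end, with a 29-fold lower number from compound 1 to compound 3 (1.46 log units; beyond the scatter), a large step. Among the compounds with values here, no measured pair exchanges chloro for fluoro, so the place of compound 4 relative to compound 2 remains open. Its number is expected to lie above that of compound 3, probably near or somewhat above that of compound 2, and still below that of compound 1.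

The expected step is a 10-fold higher number from compound 3 to compound 4 (1.00 log units; beyond the scatter), which would lie beyond the scatter. The estimate for compound 4 is 20000 nM, with an expected range of 8000 nM to 50000 nM.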

Compound 4, concentration for 50% growth inhibition: 7000 nM
Estimate against measurement, compound 4: 2.9-fold (0.46 log units) above; measured number below the stated range.
By their numbers in this assay, from the lowest: compound 3; then compounds 4 and 2 (each within the scatter of the next); then compound 1.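

In this assay, one fluoro substituent alone already produces a clear gain (an 8.3-fold lower number from compound 1 to compound 4 (0.92 log units; beyond the scatter)), so this place on the chain tolerates a much smaller halogen change than the pentafluorophenyl group and still responds. Chloro and fluoro are not told apart here (a 1.4-fold lower number from compound 2 to compound 4 (0.15 log units; within the scatter)), which means that the 3-chlorophenyl and 3-fluorophenyl groups stand on an equal footing in this read-out and the identity of this one halogen does not decide the result among these compounds. The 2,3,4,5,6-pentafluorophenyl group nevertheless keeps a lead that lies beyond the scatter (a 3.5-fold higher number from compound 3 to compound 4 (0.54 log units; beyond the scatter)), so replacing it with 3-fluorophenyl gives back part of the gain and compound 3 remains the most potent of the four.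

No supporting data accompany these numbers to explain the steps. Going by these compounds, it remains open whether the advantage of compound 3 follows from the count of fluorine atoms or from their particular places on the ring, and how a methoxy group or an amine in place of the halogen would read in this assay.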